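Bromo in Place of Hydrogen on a Chalcone Series

The compounds below may be only part of what the source reports. "The series", "measured", "known", "first", "only" and "open" are said of these compounds alone.

Among the compounds with values here, compound 2 `COc1cc(OC)c(C(=O)/C=C/c2ccccc2)c(OC)c1` is the only compound in this set with a reported number. In a functional assay on NCI-H727 cells (Homo sapiens), read by fluorescence and BrdU incorporation, with a stated time of 48 h, tested at 10 uM (a lower number here means a stronger effect, a higher number a weaker effect of the compound at the concentration tested), compound 2 gives 34%. Compound 1 `COc1cc(O)c(C(=O)/C=C/c2ccc(F)cc2)c(OC)c1` has no number at all; in this assay compound 1 is reported as "not active" (no number reported). Within the data shown here, because the two compounds differ in more than one place, nothing about a single change can be read from that pair, and no step between measured compounds is available.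

Compound 3 `COc1cc(OC)c(C(=O)/C=C/c2ccc(Br)cc2)c(OC)c1` has not yet been measured. It differs from compound 2 in one place: bromo in place of hydrogen on an aromatic carbon. The bromo group sits on an aromatic carbon of a six-membered aromatic ring of carbon only, para to a large group.

Among the measured compounds shown here, with no measured step to lean on, the expected change from compound 2 to compound 3 is small, a number 6 percentage points higher from compound 2 to compound 3 (within the scatter), and may well stay within the scatter in either direction. For compound 3 the estimate in this assay is 40%, with a range from 15% to 75%.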

Compound 3, a percentage reported as activity, at one concentration (the size of the read-out at that concentration, not a potency): 39%
Beside the measured number, compound 3's estimate is 1 percentage points above it; the range from low to high includes it.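

Bromo in place of hydrogen on this aromatic carbon gives a number 5 percentage points higher from compound 2 to compound 3 (within the scatter) and is the first change in this set that can be read on its own in this assay. It shows that this carbon of the ring can carry one heavy atom, a bromine, with a read-out that cannot be told apart from that of the unsubstituted phenyl compound, so phenyl to 4-bromophenyl makes no clear difference at the single concentration tested. Nothing available here bears on why this is so.

One substituent at one position is a narrow test, and a read-out at a single concentration is not a potency, so the two compounds could still differ at other concentrations. As far as these compounds go, it remains open whether an amine, a carboxylic acid or a longer chain on the same carbon would also give a value close to those of compound 2 and compound 3, or whether such a group would move the read-out beyond the usual scatter.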